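A few compounds are considered here, and "the series" means these few. Any claim that something is new, unique, unknown or untested is made for them only; others in the source may bear on it.

In a toxicity assay on THP-1 cells (Homo sapiens) for cytotoxicity (a higher number here means that more compound is needed for the effect, a lower number that less compound is needed), compound 2 `Cc1n[nH]c(-c2ncc3cccnc3c2O)n1` gives > 50100 nM as its reading, which is a limit and not a number. Compound 1 `Oc1c(-c2nc(C(O)c3ccccc3)n[nH]2)ncc2cccnc12` gives > 50100 nM as its reading, also a limit. Compound 3 `O=C1CCCN1Cc1n[nH]c(-c2ncc3cccnc3c2O)n1` gives > 50100 nM as its reading, again a limit. Compound 2 therefore has no number of its own to start from. Compound 4 `Cc1n[nH]c(-c2ncc3c(-c4ccccc4)ccnc3c2O)n1` departs from compound 2 in one place, and phenyl in place of hydrogen on an aromatic carbon describes it: phenyl in place of hydrogen on an aromatic carbon, opposite the ring nitrogen.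

The measured steps are a step that the two limits leave unreadable from compound 1 to compound 2 and a step that the two limits leave unreadable from compound 1 to compound 3 and a step that the two limits leave unreadable from compound 2 to compound 3 and all three leave the shared core untouched. None of them gives a size for this change. The record holds only the limit of > 50100 nM in this assay, at which 3 of the 3 values shown sit, and that sets no size. In this assay a modest move toward lower numbers, if any, is expected. The expected change is an at least 1.2-fold lower number from compound 2 to compound 4 (0.09 log units; that floor lies within the scatter) and it remains an estimate. Compound 4 is estimated at 40000 nM with an expected range from 12000 nM to 100000 nM on this reasoning.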

Compound 4, half-maximal effective concentration in the THP-1 assay: > 50100 nM
Compound 4 was reported as a limit; the forecaster's own chance of this, stated with the estimate: 60%; middle value at least 1.2-fold (0.09 log units) away from the limit.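

No new step can be read between compound 2 and compound 4: in the THP-1 assay both readings are limits. In a physicochemical assay for lipophilicity, at pH 7.4 (on this read-out higher numbers stand for higher lipophilicity and lower numbers for lower lipophilicity), compound 2 gives 0.73 as its reading, while compound 4 gives "not determined" (no result reported) as its entry, with no result reported. The compounds shown leave open how far phenyl at this place changes either read-out.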